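Swapping ethyl for methylamino on a sulfonyl sulfur

This account rests on a few compounds, and the source may have more. Where it says the series, first, only, none or still open, it means among the compounds named here.

Of the compounds shown here, three have been tested so far in an in vitro ADME assay on microsomes from liver (Homo sapiens) for metabolic stability; a lower number here means slower removal, a higher number faster removal of the compound. Compound 1 `Cc1cnc(NC(=O)c2cc(Oc3cnc(C(=O)N(C)C)cn3)c3cc(C)oc3c2)cn1` gives < 8 mL/min/kg, and this is a limit of the assay rather than a number. Compound 2 `Cc1cnc(NC(=O)c2cc(Oc3cnc(C(=O)N(C)C)cn3)c3cc(C)nn3c2)cn1`, by contrast, gives a measured number, 13.7 mL/min/kg. Compound 3 `CCS(=O)(=O)c1ccc(Oc2cc(C(=O)Nc3cnc(C)cn3)cc3nn(C)cc23)cc1` gives < 8 mL/min/kg, which is again a limit. Compound 3 therefore stands at the limit of < 8 mL/min/kg in this assay, at which 2 of the 3 values shown sit.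

Compound 4 `CNS(=O)(=O)c1ccc(Oc2cc(C(=O)Nc3cnc(C)cn3)cc3nn(C)cc23)cc1` keeps the core of compound 3 and changes one group, with methylamino in place of ethyl on a sulfonyl sulfur. Among the measured compounds shown here, no two measured compounds differ by this same change, so there is no direct precedent for the size of the step in this assay. The expectation is therefore a cautious one: a small rise at most, probably no step beyond the usual scatter. For the measured compounds named here, the only measured number, from compound 2 at 13.7 mL/min/kg, serves as a rough guide to the upper end. The estimated change is an at least 1.1-fold higher number from compound 3 to compound 4 (0.05 log units; that floor lies within the scatter). Compound 4 is expected at about 9 mL/min/kg, with an estimated range of 6 mL/min/kg to 16 mL/min/kg, and it may well return only a limit again.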

Compound 4, clearance: < 8.6 mL/min/kg
Compound 4: a limit, no number (the forecaster's own chance of this, stated with the estimate: 55%); at least 1.0-fold (0.01 log units) between middle value and limit.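

In this assay, compound 3 and compound 4 both return only a limit rather than a number, so no step can be read for the swap of ethyl for methylamino on a sulfonyl sulfur. The compounds shown leave open whether this swap changes clearance at all and, if it does, in which direction and by how much.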